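Nitro to hydroxy on the aryl ring: an expected small step

A few compounds are considered here, and "the series" means these few. Any claim that something is new, unique, unknown or untested is made for them only; others in the source may bear on it.

Compound 1, `Cc1ccc(/C=C(\C#N)C(=O)Nn2c(C)nc3ccc(C)cc3c2=O)cc1`, in a functional assay on HeLa cells (Homo sapiens) for cytotoxicity, read by MTT assay, with a stated time of 3 days; on this read-out higher numbers stand for weaker inhibition and lower numbers for stronger inhibition: 9000 nM
Compound 2, `Cc1ccc2nc(C)n(NC(=O)/C(C#N)=C/c3ccc([N+](=O)[O-])cc3)c(=O)c2c1`, in this assay : 15000 nM

Going by the values given here, compound 2 holds the highest of the two numbers, with compound 1 as its only neighbour; the step of a 1.7-fold higher number from compound 1 to compound 2 (0.22 log units; within the scatter) is within the scatter, so the two compounds cannot be ordered.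

Compound 3, `Cc1ccc2nc(C)n(NC(=O)/C(C#N)=C/c3ccc(O)cc3)c(=O)c2c1`, differs from compound 2 by hydroxy in place of nitro on an aromatic carbon. Among the compounds with values here, the only measured step that bears on this position is the one from compound 1 to compound 2, where a nitro replaced a methyl on the same aromatic carbon and the number barely moved. Within the data shown here, no measured pair shows a hydroxy at that place, so the expectation rests on that single small step alone. With one exchange at this carbon already lying within the scatter, the exchange to hydroxy is expected to give no step beyond the scatter either, that is a 1.5-fold lower number from compound 2 to compound 3 (0.18 log units; within the scatter).

For compound 3 in this assay the estimate is therefore 10000 nM, within a range from 3000 nM to 35000 nM.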

Compound 3, half-maximal inhibitory concentration: 13000 nM
Compound 3: middle estimate off by 1.3-fold (0.11 log units), on the low side; measured number inside the range.
By their numbers in this assay, from the lowest: compounds 1, 3 and 2 (each within the scatter of the next).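

In this assay the change from 4-nitrophenyl to 4-hydroxyphenyl gives a 1.2-fold lower number from compound 2 to compound 3 (0.06 log units; within the scatter) and so adds a second exchange at this aromatic carbon with no readable effect, even though the entering hydroxy is a hydrogen-bond donor and the leaving nitro is not. The comparison with the methyl group gives a 1.4-fold higher number from compound 1 to compound 3 (0.16 log units; within the scatter) and closes the set: each pair among compound 1, compound 2 and compound 3 lies within the scatter, so methyl, nitro and hydroxy cannot be ordered at this place on the ring, and this cytotoxicity read-out does not separate these three groups. No measurement available here offers a reason for this flat picture.

The compounds shown leave open whether an amine or a carboxylic acid on the same carbon, para to the large group, would also stay within the scatter, or whether a larger group such as a longer alkoxy chain would finally produce a readable step. They also leave open whether any of these three groups would behave the same way on another carbon of this ring.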